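This account rests on a few compounds, and the source may have more. Where it says the series, first, only, none or still open, it means among the compounds named here.

Measured so far in a functional assay on HepG2 cells (Homo sapiens) for cytotoxicity, with a stated time of 72 h; on this read-out higher numbers stand for an effect only at larger amounts of compound and lower numbers for an effect already at smaller amounts:
- compound 1 `C=C[C@@](C)(/C=C/c1ccc(O)c(/C=C/C#N)c1)CCC=C(C)C`: > 52000 nM
- compound 2 `C=C[C@@](C)(/C=C/c1ccc(O)c(/C=C(\C)C(=O)OCC)c1)CCC=C(C)C`: > 52000 nM
- compound 3 `COc1ccc(/C=C/[C@@](C)(/C=C/c2ccc(O)c(/C=C/C#N)c2)CCC=C(C)C)cc1`: > 26000 nM

Each of these entries is a limit of the assay and not a number. Compound 3 stands at the limit of > 26000 nM in this assay, at which 1 of the 3 values shown sits. Compound 1 and compound 2 stand at the limit of > 52000 nM in this assay, at which 2 of the 3 values shown sit. Among the measured compounds shown here, no compound therefore has a readable place relative to the others.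

The next compound is compound 4 `CCOC(=O)/C(C)=C/c1cc(/C=C/[C@](C)(/C=C/c2ccc(OC)cc2)CCC=C(C)C)ccc1O`, still unmeasured. It differs from compound 3 as follows: 2-(ethoxycarbonyl)prop-1-en-1-yl in place of 2-cyanoethenyl on an aromatic carbon. The same exchange on the aromatic carbon appears in a step that the two limits leave unreadable from compound 1 to compound 2. The other measured change, 2-(4-methoxyphenyl)ethenyl in place of vinyl, appears in a step that the two limits leave unreadable from compound 1 to compound 3, and compound 4 keeps that group. Neither step gives a size to carry over, so no change beyond the scatter is expected in this assay, in either direction. The expected outcome is a step that the limit leaves unreadable from compound 3 to compound 4. This expectation starts from compound 3, which gives > 26000 nM, a limit. Another limit is the likeliest report. For compound 4 the estimate is 30000 nM, with an expected range of 12000 nM to 60000 nM.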

Compound 4, half-maximal effective concentration: > 52000 nM
Compound 4: only a limit was reported; the forecaster's own chance of this, stated with the estimate: 75%; middle value at least 1.7-fold (0.23 log units) from the limit.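

In this assay compound 4 gives > 52000 nM, a limit of the assay and not a number. With compound 2 and compound 3 also reported only as limits, neither step to compound 4 can be read. The compounds shown leave open whether either exchange changes the response in this assay at all.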